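The compounds below may be only part of what the source reports. "The series", "measured", "known", "first", "only" and "open" are said of these compounds alone.

In a toxicity assay on NIH3T3 cells (Mus musculus) for cytotoxicity, read by resazurin assay (on this read-out higher numbers stand for an effect only at larger amounts of compound and lower numbers for an effect already at smaller amounts), compound 1 (`COC(=O)c1ccc(NCc2cncn2Cc2ccc(Cl)cc2)cc1-c1ccccc1`) gives 25000 nM, the highest number of the three measured, while compound 2 (`COC(=O)c1ccc(NCc2cncn2Cc2ccccc2C)cc1-c1ccccc1`) gives 10000 nM and compound 3 (`COC(=O)c1ccc(NCc2cncn2Cc2ccccc2Cl)cc1-c1ccccc1`) gives 10000 nM. Compound 4 (`Clc1ccc(Cn2cncc2CNc2ccc(-c3nc4ccccc4s3)c(-c3ccccc3)c2)cc1`) is still unmeasured and differs from compound 1 as follows: 1,3-benzothiazol-2-yl in place of methoxycarbonyl on an aromatic carbon. In short, 1,3-benzothiazol-2-yl stands in place of methoxycarbonyl on an aromatic carbon, ortho to a phenyl group.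

The measured steps all exchange the substituted phenyl on a saturated chain carbon bound to an aromatic nitrogen: a 2.5-fold lower number from compound 1 to compound 2 (0.40 log units; beyond the scatter), a 2.5-fold lower number from compound 1 to compound 3 (0.40 log units; beyond the scatter) and no change at the digits printed from compound 2 to compound 3 (within the scatter). None touches the methoxycarbonyl, so they offer only a scale of size, and no measured change exists at this place. With compound 1 at 25000 nM, the top of the measured values, a modest move to a lower number is expected in this assay. The expected step is a 2.1-fold lower number from compound 1 to compound 4 (0.32 log units; beyond the scatter). For compound 4 the estimated value is 12000 nM, with an expected range of 4000 nM to 35000 nM.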

Compound 4, half-maximal effective concentration: > 1000 nM
Compound 4: a limit, no number; the forecaster's own chance of this, stated with the estimate: 25%; the middle value is on the limit's open side.
By their numbers in this assay, from the lowest: compounds 2 and 3 (each within the scatter of the next); then compound 1.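

In this assay compound 4 gives > 1000 nM, a limit and not a number. Among the compounds shown here, no step between compound 1 and compound 4 can be read from it. The compounds shown leave open the size and direction of any change when 1,3-benzothiazol-2-yl replaces methoxycarbonyl.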